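A few compounds are considered here, and "the series" means these few. Any claim that something is new, unique, unknown or untested is made for them only; others in the source may bear on it.

Compound 1 `CCOC(=O)c1cnc(-c2ccccc2)nc1NN1C(=O)C=C(C)C1=O`: 100 nM
Compound 2 `CCOC(=O)c1cnc(-c2ccncc2)nc1NN1C(=O)C=C(C)C1=O`: 6000 nM
Compound 3 `CCOC(=O)c1cnc(-c2ccc(C(F)(F)F)cc2)nc1NN1C(=O)C=C(C)C1=O`: 400 nM

In a functional assay on Jurkat cells for inhibition of nuclear factor NF-kappa-B complex (Homo sapiens) (a higher number here means a weaker inhibitor, a lower number a stronger inhibitor), compound 1 gives 100 nM, the lowest number of the three; compound 3 follows at 400 nM and compound 2 at 6000 nM. Compound 4 `CCOC(=O)c1cnc(-c2ccc(C)s2)nc1NN1C(=O)C=C(C)C1=O` has not yet been measured. It differs from compound 1 in one place: 5-methylthiophen-2-yl in place of phenyl on an aromatic carbon. Two measured steps change the same place of the shared core. Putting pyridin-4-yl in place of phenyl gave a 60-fold higher number from compound 1 to compound 2 (1.78 log units; beyond the scatter), while adding trifluoromethyl to the phenyl gave a 4.0-fold higher number from compound 1 to compound 3 (0.60 log units; beyond the scatter). Both changes weakened inhibition, and pyridin-4-yl did so far more than trifluoromethyl. The 5-methylthiophen-2-yl group brings one hetero atom and one hydrogen-bond acceptor, yet it is a five-membered ring and not the six-membered one with nitrogen, so the change is not the one that gave a 60-fold higher number from compound 1 to compound 2 (1.78 log units; beyond the scatter). A modest weakening is therefore expected for compound 4, a 2.5-fold higher number from compound 1 to compound 4 (0.40 log units; beyond the scatter). Compound 4 is estimated at 250 nM, within 80 nM to 1000 nM.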

Compound 4, half-maximal inhibitory concentration: 200 nM
Compound 4: the middle estimate sits 1.3-fold (0.10 log units) above what was measured; measured number inside the range.
By their numbers in this assay, from the lowest: compounds 1, 4 and 3 (each within the scatter of the next, the first and the last beyond it); then compound 2.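

In this assay, putting 5-methylthiophen-2-yl in place of phenyl gives a 2.0-fold higher number from compound 1 to compound 4 (0.30 log units; within the scatter), so this position accepts a five-membered aromatic ring with sulfur as well as a six-membered carbon ring. Putting the same group in place of 4-(trifluoromethyl)phenyl gives a 2.0-fold lower number from compound 3 to compound 4 (0.30 log units; within the scatter), while putting it in place of pyridin-4-yl gives a 30-fold lower number from compound 2 to compound 4 (1.48 log units; beyond the scatter). A hetero atom in this ring therefore does not by itself bring the large loss seen with pyridin-4-yl, since the thiophene of compound 4 carries one too.

As far as these compounds go, it remains open whether an amine or a carboxylic acid on this ring would be accepted, and whether a ring is needed here at all rather than a longer carbon chain. Nothing available here explains the differences among these groups.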